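A second fluorine on a weak histone deacetylase 8 inhibitor

A few compounds are considered here, and "the series" means these few. Any claim that something is new, unique, unknown or untested is made for them only; others in the source may bear on it.

Compound 3 `O=C1NC(=O)/C(=C\c2ccc(OCC(=O)N3N=C(c4ccc(F)cc4)CC3c3ccc(F)cc3)cc2)S1` gives only > 50000 nM in an assay on cells for inhibition of histone deacetylase 8 (Homo sapiens), read by fluorescence, with a stated time of 30 min (on this read-out higher numbers stand for weaker inhibition and lower numbers for stronger inhibition), which is a limit of the assay and not a number. Compound 1 `O=C1NC(=O)/C(=C\c2ccc(OCC(=O)N3N=C(c4ccccc4)CC3c3ccc(F)cc3)cc2)S1` gives 26000 nM in this assay. Compound 2 `O=C1NC(=O)/C(=C\c2ccc(OCC(=O)N3N=C(c4ccc(F)cc4)CC3c3ccco3)cc2)S1` likewise gives only a limit in this assay, > 50000 nM. For the measured compounds named here, the step of an at least 1.9-fold higher number from compound 1 to compound 3 (0.28 log units; that floor lies within the scatter) is the one readable comparison, while the step that the two limits leave unreadable from compound 2 to compound 3 cannot be sized because the limit of > 50000 nM in this assay, at which 2 of the 3 values shown sit, holds both values. Compound 4 `O=C1NC(=O)/C(=C\c2ccc(OCC(=O)N3N=C(c4ccc(F)cc4F)CC3c3ccc(F)cc3)cc2)S1` differs from compound 3 by fluoro in place of hydrogen on an aromatic carbon. Because the step of an at least 1.9-fold higher number from compound 1 to compound 3 (0.28 log units; that floor lies within the scatter) already runs toward weaker inhibition and ends at a limit, compound 4 is expected to remain at or beyond that limit, a step that the limit leaves unreadable from compound 3 to compound 4. The estimate for compound 4 is 70000 nM, spanning 30000 nM to 200000 nM.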

Compound 4, half-maximal inhibitory concentration: > 50000 nM
Compound 4 ended at the assay's limit; the forecaster's own chance of this, stated with the estimate: 80%; the middle value is on the limit's open side.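

In this assay a second fluoro on this aromatic ring, ortho to a large group, leaves compound 4 at a limit and not at a number, so this change brings no readable inhibition back. For the compounds shown here, the step of an at least 1.9-fold higher number from compound 1 to compound 4 (0.28 log units; that floor lies within the scatter) is the only readable one for compound 4. The step between compound 3 and compound 4 cannot be read because both sit at the same limit: the limit of > 50000 nM in this assay, at which 3 of the 4 values shown sit.

From the compounds shown here alone, how far beyond that limit either compound lies stays open. So does whether an amine or a carboxylic acid in place of the fluoro would give a measurable value.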